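Fused Ring Replaces Fluorophenyl in a Bis-indole Amide Series

The source may report more compounds than this note shows. Statements on the series, on what has been measured and on what is new or still open speak of the compounds shown alone.

Measured compounds:
compound 1 `CN1[C@@H]2c3[nH]c4ccccc4c3C[C@H]1[C@H](C#N)N1[C@@H](CNC(=O)c3ccc(Cl)cc3)c3[nH]c4ccccc4c3C[C@@H]21` — 130 nM
compound 2 `COc1ccc(C(=O)NC[C@H]2c3[nH]c4ccccc4c3C[C@H]3[C@H]4c5[nH]c6ccccc6c5C[C@@H]([C@H](C#N)N23)N4C)cc1` — 840 nM
compound 3 `CN1[C@@H]2c3[nH]c4ccccc4c3C[C@H]1[C@H](C#N)N1[C@@H](CNC(=O)c3ccc(F)cc3)c3[nH]c4ccccc4c3C[C@@H]21` — 1370 nM

Three amides on a shared core were tested in a functional assay on HT-29 cells (Homo sapiens) for cytotoxicity, read by MTT assay, with a stated time of 72 h; a higher number here means a weaker inhibitor, a lower number a stronger inhibitor. Compound 3 gives the highest number of the three: the step of an 11-fold higher number from compound 1 to compound 3 (1.02 log units; beyond the scatter) is beyond the scatter, while compound 2 and compound 3 sit within the scatter of each other, as a 1.6-fold higher number from compound 2 to compound 3 (0.21 log units; within the scatter) shows. Compound 2 also falls short of compound 1, by a 6.5-fold higher number from compound 1 to compound 2 (0.81 log units; beyond the scatter).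

Compound 4 `CN1[C@@H]2c3[nH]c4ccccc4c3C[C@H]1[C@H](C#N)N1[C@@H](CNC(=O)c3cccc4c3CCCC4)c3[nH]c4ccccc4c3C[C@@H]21` differs from compound 3 by 1,2,3,4-tetrahydronaphthalen-5-yl in place of 4-fluorophenyl on a carbonyl carbon. The measured steps all swap one substituent on the phenyl ring; none adds a second ring, so they bear on the new change only indirectly. They do show that the amide aryl portion moves the numbers in this assay by a modest to large amount, and that the fluoro compound 3 is the weakest point among them. On this basis compound 4 is expected to move back toward the value of compound 1, and the step of a 2.7-fold lower number from compound 3 to compound 4 (0.44 log units; beyond the scatter) is estimated as a lower number, though with wide uncertainty. The value of compound 4 is estimated at 500 nM, within a range of 120 nM to 2500 nM.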

Compound 4, half-maximal inhibitory concentration: 3340 nM
Compound 4: middle estimate off by 6.7-fold (0.82 log units), on the low side; the whole stated range lies below it.
By their numbers in this assay, from the lowest: compound 1; then compounds 2 and 3 (each within the scatter of the next); then compound 4.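

In this assay, putting 1,2,3,4-tetrahydronaphthalen-5-yl in place of 4-fluorophenyl on the carbonyl carbon gives a 2.4-fold higher number from compound 3 to compound 4 (0.39 log units; beyond the scatter), so the fluoro compound no longer marks the top of the range at this position. For the compounds shown here, the other two comparisons show the same direction, with a 4.0-fold higher number from compound 2 to compound 4 (0.60 log units; beyond the scatter) and a 26-fold higher number from compound 1 to compound 4 (1.41 log units; beyond the scatter); compound 4 is therefore the weakest inhibitor of the four, and this position spans a wider range than the single substituent swaps on the phenyl ring had revealed. Adding a non-aromatic carbon ring to the aryl group, with no hydrogen-bond donor or acceptor entering, did not bring the number back toward that of compound 1, and nothing available here explains the rise.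

Because the change removes the fluoro group and adds the second ring in one step, the compounds shown cannot separate the two contributions. On these data alone, it also remains open how a plain phenyl, a bromo group, or a carboxylic acid or an amine on the aryl ring would read in this assay.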